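Naphthyl in place of cyanobenzyl: solubility notes

This account rests on a few compounds, and the source may have more. Where it says the series, first, only, none or still open, it means among the compounds named here.

Compound 1 `COc1ccc(F)cc1CNCCCNc1ccnc2cc(Cc3ccc(C#N)cc3)ccc12` in a physicochemical assay for solubility, with a stated time of 18 h, at pH 7.4 (on this read-out lower numbers stand for lower solubility and higher numbers for higher solubility), gives 4200 nM. Compound 2 `Cc1cc(C)cc(Cc2ccc3c(NCCCNCc4ccco4)ccnc3c2)c1` gives 4200 nM and compound 3 `COc1cccc(CNCCCNc2ccnc3cc(Cc4ccc(C#N)cc4)ccc23)c1O` gives 4200 nM; compound 1 stands level with both at the digits shown, so no ordering among the three is claimed. For the measured compounds named here, the only single-point step measured, no change at the digits printed from compound 1 to compound 3 (within the scatter), exchanges the aryl group on the saturated chain carbon bound to an amine nitrogen and leaves the read-out unchanged.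

Compound 4 `COc1ccc(F)cc1CNCCCNc1ccnc2cc(-c3cccc4ccccc34)ccc12` differs from compound 1 at another site: naphthalen-1-yl in place of 4-cyanobenzyl on an aromatic carbon. Going by the values given here, no measured step touches that aromatic carbon; the step from compound 1 to compound 3 concerns a different part of the molecule and gives no guide to size or direction here. The replacement removes the one hydrogen-bond acceptor counted and brings in a second six-membered aromatic ring of carbon only. With nothing measured to anchor it, a fall in solubility beyond the scatter is expected, of moderate size, and the broad range reflects that. For compound 4 the expected step is a 4.7-fold lower number from compound 1 to compound 4 (0.67 log units; beyond the scatter). The estimate for compound 4 in this assay is 900 nM, with a range from 150 nM to 4200 nM.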

Compound 4, solubility: 32000 nM
Compound 4: middle estimate off by 36-fold (1.55 log units), on the low side, and the stated range ends below it.
By their numbers in this assay, from the lowest: compounds 1, 2 and 3 (each within the scatter of the next); then compound 4.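

In this assay, for the compounds shown here, the aromatic carbon bearing 4-cyanobenzyl emerges as a place where the read-out can move: naphthalen-1-yl there gives a 7.6-fold higher number from compound 1 to compound 4 (0.88 log units; beyond the scatter), whereas the one earlier step, no change at the digits printed from compound 1 to compound 3 (within the scatter), lay on the aryl group of the side chain and left the number level. The direction also matters at this position, since the change takes out the nitrile with its hydrogen-bond acceptor and brings in a second six-membered aromatic ring of carbon only, yet the number rises, though this single pair cannot separate those two changes from each other. No measured property on hand bears on why the number rises.

Open, from the compounds shown here alone, is whether the rise follows naphthalen-1-yl itself or the loss of the 4-cyanobenzyl group, a question that a plain benzyl, a phenyl or a naphthalen-2-yl at the same aromatic carbon would help to settle. Also open, going by these compounds, is whether the same exchange gives a step of similar size with the 2-hydroxy-3-methoxyphenyl group of compound 3 on the side chain, or with a ring bearing a carboxylic acid or an amine at this position.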